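A Larger Tail on a Weak Platelet Inhibitor

A few compounds are considered here, and "the series" means these few. Any claim that something is new, unique, unknown or untested is made for them only; others in the source may bear on it.

This small set concerns amides built on a shared core. Compound 1 `N=C(N)N1CCCC(C(=O)Nc2cccc(OCc3ccc(F)cc3)c2)C1` and compound 2 `O=C(Nc1cccc(OCc2ccccc2)c1)C1CCNCC1` belong to it, but in a functional assay on a cell-free system (Platelet, plasma, Homo sapiens) for inhibition (on this read-out higher numbers stand for weaker inhibition and lower numbers for stronger inhibition), compound 1 gives "not determined" (no result reported) and compound 2 gives "not determined" (no result reported), so neither has a result to show. Among the compounds with values here, compound 3 `O=C(Nc1cccc(OCc2ccc(F)cc2)c1)C1CCNCC1` is the only member with a number: in this assay compound 3 gives 36000 nM, which places it among very weak inhibitors. Compound 3 therefore stands alone; there is no second number to rank it against.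

Compound 4 `O=C(Nc1cccc(OCc2ccc(-c3ccc(F)cc3)cc2)c1)C1CCNCC1` differs from compound 3 in a single place (4-fluorophenyl in place of fluoro on an aromatic carbon). The fluoro group at the end of the molecule is exchanged for a 4-fluorophenyl group, so the outer ring carries a second ring in its place.

Within the data shown here, with no measured pair of this kind to lean on, the direction of the step is uncertain. The larger group may be tolerated or may help a little; a loss is also possible. The step from compound 3 to compound 4 is estimated at a 2.4-fold lower number from compound 3 to compound 4 (0.38 log units; beyond the scatter), a modest gain that could still fall within the usual scatter. In this assay compound 4 is expected to give 15000 nM, with a likely range from 3000 nM to 80000 nM.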

Compound 4, half-maximal inhibitory concentration: 19000 nM
Estimate against measurement, compound 4: 1.3-fold (0.10 log units) below; low and high end bracket the measured number.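

In this assay the step is a 1.9-fold lower number from compound 3 to compound 4 (0.28 log units; within the scatter) and therefore gives no firm sign of either a gain or a loss. The position on the outer ring can thus carry 4-fluorophenyl, with seven heavy atoms and a second aromatic ring, in place of fluoro, a single heavy atom, without a change that can be told from the ordinary variation between repeated measurements. Both compounds remain very weak inhibitors, and no supporting measurement is available to explain why the larger group makes so little measurable difference.

This single pair cannot show whether other groups at this position would move the number beyond the scatter, such as a carboxylic acid, an aminomethyl group or a longer alkyl chain. It also leaves open whether a change elsewhere, for example an amine on the linker between the two aromatic rings or a different group on the nitrogen of the shared core, would turn these weak inhibitors into substantially stronger ones.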